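Working notes: methoxy on the phenyl of compound 3

The source may hold more compounds than are shown below. What is called first, only, known or untested is meant among the compounds shown, and "the series" means these compounds.

Measured in a functional assay on MDA-MB-231 cells (Homo sapiens) for antiproliferative activity, with a stated time of 5 days; a lower number here means a stronger inhibitor, a higher number a weaker inhibitor:
- compound 1 `COc1ccc(-n2nc(-c3ccc4ccccc4c3)nc2N2C(=O)COC23C=CC(=O)C=C3)cc1`: 60 nM
- compound 2 `CC1OC2(C=CC(=O)C=C2)N(c2nc(-c3ccc4ccccc4c3)nn2-c2ccc3ccccc3c2)C1=O`: 60 nM
- compound 3 `CC1OC2(C=CC(=O)C=C2)N(c2nc(-c3ccc4ccccc4c3)nn2-c2ccccc2)C1=O`: 70 nM

Compound 3 lies within the scatter of both compound 1 and compound 2, so this assay does not separate the three. Next is compound 4 `COc1ccc(-n2nc(-c3ccc4ccccc4c3)nc2N2C(=O)C(C)OC23C=CC(=O)C=C3)cc1`, with phenyl to 4-methoxyphenyl: methoxy in place of hydrogen on an aromatic carbon. Among the compounds with values here, the only measured step on this aryl group is a 1.2-fold higher number from compound 2 to compound 3 (0.07 log units; within the scatter), which replaces naphthalen-2-yl with phenyl on an aromatic nitrogen. Compound 1, which also carries 4-methoxyphenyl, gives 60 nM. On this evidence, no step beyond the scatter is expected in this assay. The estimated step is a 1.1-fold lower number from compound 3 to compound 4 (0.03 log units; within the scatter). For compound 4 the expected value is 65 nM, with an expected range of 30 nM to 140 nM.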

Compound 4, half-maximal inhibitory concentration: 50 nM
For compound 4 the middle estimate is 1.3-fold (0.11 log units) above the measured one; the measured number falls inside the stated range.
By their numbers in this assay, from the lowest: compounds 4, 1, 2 and 3 (each within the scatter of the next).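

In this assay, within the data shown here, methoxy in place of hydrogen, para to a large group, gives the first direct reading at this position, and it stays within the scatter (a 1.4-fold lower number from compound 3 to compound 4 (0.15 log units; within the scatter)). Two further changes also stay within the scatter: 4-methoxyphenyl in place of naphthalen-2-yl (a 1.2-fold lower number from compound 2 to compound 4 (0.08 log units; within the scatter)) and methyl in place of hydrogen on a saturated ring carbon (a 1.2-fold lower number from compound 1 to compound 4 (0.08 log units; within the scatter)). No supporting data bear on the origin of these steps.

From the compounds shown here alone, whether an amine or a carboxylic acid at this aromatic carbon would give a step beyond the scatter remains open. So does the effect of a longer chain in place of the methyl.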